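A few compounds are considered here, and "the series" means these few. Any claim that something is new, unique, unknown or untested is made for them only; others in the source may bear on it.

Compound 1 `COc1cccc(N2C(=O)COc3ccc(-c4cnc(Cl)c(NS(=O)(=O)c5ccc(F)cc5)c4)cc32)c1`: 32700 nM
Compound 2 `Cc1ccc(N2C(=O)COc3ccc(-c4cnc5ccccc5c4)cc32)cc1`: > 40000 nM

In a functional assay on A549 cells (Homo sapiens) for antiproliferative activity, read by MTT assay, with a stated time of 72 h (on this read-out higher numbers stand for weaker inhibition and lower numbers for stronger inhibition), compound 1 gives 32700 nM. For the measured compounds named here, this is the only number reported for the shared core; the remaining entry is a limit of the assay. Compound 2 stops at > 40000 nM, which is a limit rather than a number, as shown by the limit of > 40000 nM in this assay, at which 1 of the 2 values shown sits. Going by the values given here, compound 1 therefore stands alone as the sole measured value, and it sits close to that limit. Among the compounds with values here, no two measured compounds differ in a single place, so no measured step exists to guide expectations.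

Compound 3 `CC(C)N1C(=O)COc2ccc(-c3cnc(Cl)c(NS(=O)(=O)c4ccc(F)cc4)c3)cc21` differs from compound 1 in one place: isopropyl in place of 3-methoxyphenyl on an amide-type nitrogen in a ring. Within the data shown here, with no measured step of this kind, the change from compound 1 to compound 3 is expected to fall within the usual scatter, or to weaken inhibition slightly; nothing in the data points to a gain. Compound 3 is accordingly estimated at 45000 nM, within 15000 nM to 150000 nM. The expected step is a 1.4-fold higher number from compound 1 to compound 3 (0.14 log units; within the scatter). Since compound 1 gives 32700 nM, already a weak result in this assay, there is a fair chance that compound 3 will give no number at all.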

Compound 3, half-maximal inhibitory concentration: 5100 nM
Compound 3: middle estimate off by 8.8-fold (0.95 log units), on the high side; measured number below the stated range.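

In this assay, the amide-type nitrogen in a ring proves to be a place where a single change moves the read-out, with isopropyl in place of 3-methoxyphenyl giving a 6.4-fold lower number from compound 1 to compound 3 (0.81 log units; beyond the scatter). The earlier compounds shown here offered no measured step of this kind, and compound 3, at 5100 nM, shows that on this core the six-membered aromatic ring of 3-methoxyphenyl is not needed on this nitrogen, since a group with no ring gives the stronger inhibition of the pair. For compound 2 the read-out remains a limit and not a number, so it offers no comparison here: the limit of > 40000 nM in this assay, at which 1 of the 3 values shown sits.

This one step removes the ring, the hydrogen-bond acceptor and most of the heavy atoms of the group at once, and the data cannot separate these changes from one another. Also open, as far as these compounds go, is how the read-out would respond to a cyclopropyl group, an n-butyl chain or a 2-methoxyethyl chain on this nitrogen, and whether a still smaller group such as methyl would carry the trend further or reverse it.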